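Taking Away a Nitro Group in Two Related Pairs

The source may hold more compounds than are shown below. What is called first, only, known or untested is meant among the compounds shown, and "the series" means these compounds.

Compound 1 `O=[N+]([O-])c1ccc(COc2ccc(Nc3ncnc4cc5c(cc34)OCCOCCO5)cc2)cc1` was tested in a functional assay on MCF7 cells (Homo sapiens) for antiproliferative activity, read by MTT assay, with a stated time of 72 h (on this read-out higher numbers stand for weaker inhibition and lower numbers for stronger inhibition), where compound 1 gives 39700 nM. Compound 2 `c1ccc(COc2ccc(Nc3ncnc4cc5c(cc34)OCCOCCO5)cc2)cc1` differs from compound 1 by hydrogen in place of nitro on an aromatic carbon. In this assay compound 2 gives only a limit of the assay, > 100000 nM. The step of an at least 2.5-fold higher number from compound 1 to compound 2 (0.40 log units; beyond the scatter) therefore weakens inhibition. Compound 3 `O=[N+]([O-])c1ccc(COc2ccc(Nc3ncnc4cc5c(cc34)OCCOCCOCCOCCO5)cc2)cc1` carries the same nitro group on a different core; the difference between the two cores is not broken down here. Compound 3 gives only a limit as well, > 100000 nM. Compound 4 `c1ccc(COc2ccc(Nc3ncnc4cc5c(cc34)OCCOCCOCCOCCO5)cc2)cc1` is not yet measured and differs from compound 3 by hydrogen in place of nitro on an aromatic carbon, the same change as in the first pair. Compound 3 already rests at the limit of > 100000 nM in this assay, at which 2 of the 3 values shown sit. Since that change earlier gave an at least 2.5-fold higher number from compound 1 to compound 2 (0.40 log units; beyond the scatter), compound 4 is expected to stay beyond the limit, an estimated step that the limit leaves unreadable from compound 3 to compound 4. The estimate for compound 4 is 200000 nM, between 100000 nM and 500000 nM.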

Compound 4, half-maximal inhibitory concentration: 12000 nM
Compound 4: middle estimate off by 17-fold (1.22 log units), on the high side, and the stated range ends above it.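

Taking away the nitro group does not act alike on the two cores in this assay, where the new pair shows an at least 8.3-fold lower number from compound 3 to compound 4 (0.92 log units; beyond the scatter). Set beside the first pair, the change reverses direction: the same change on two cores in this assay, an at least 2.5-fold higher number (0.40 log units; beyond the scatter) from compound 1 to compound 2 and an at least 8.3-fold lower number (0.92 log units; beyond the scatter) from compound 3 to compound 4, at least 20-fold (1.32 log units) apart, beyond the scatter of two such steps

Compound 2 and compound 3 are each recorded only as a limit, so the true size of each step stays unknown, and two pairs do not show why the direction reverses. Open, from the compounds shown here alone, is whether an amine or a carboxylic acid in place of the nitro group would also behave differently on the two cores. Also open, going by these compounds, is which part of the two cores matters for this difference.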